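This account rests on a few compounds, and the source may have more. Where it says the series, first, only, none or still open, it means among the compounds named here.

Working notes on the series. Compound 1 `O=C1CSC(N2N=C(c3ccc(Cl)c(Cl)c3)CC2c2ccccc2)=N1` and compound 2 `Cc1cccc(C2CC(c3ccc(Cl)c(Cl)c3)=NN2C2=NC(=O)CS2)c1` share one core and differ only in the pendant aromatic ring on the saturated ring carbon. In an ADME assay on RAW264.7 cells (Mus musculus) for cytotoxicity, read by MTT assay, with a stated time of 24 h (a higher number here means that more compound is tolerated, a lower number that less compound is tolerated), compound 1 gives 295000 nM, and compound 2 gives 204000 nM. The step of a 1.4-fold lower number from compound 1 to compound 2 (0.16 log units; within the scatter) shows that the two compounds sit within the scatter of each other on this assay, so neither can be set apart from the other.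

Compound 3 `O=C1CSC(N2N=C(c3ccc(Cl)c(Cl)c3)CC2c2ccc(Cl)cc2)=N1` continues this theme: 4-chlorophenyl in place of 3-methylphenyl on a saturated ring carbon. Within the data shown here, the only measured step that bears on this change is the one from compound 1 to compound 2, where a substituent on the same pendant ring was exchanged and the number moved within the scatter. On that basis no step beyond the scatter is expected for compound 3, in either direction, and the expected step is a 1.1-fold higher number from compound 2 to compound 3 (0.03 log units; within the scatter). Compound 3 is therefore estimated at 220000 nM in this assay, with a range of 100000 nM to 450000 nM.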

Compound 3, half-maximal cytotoxic concentration: 187000 nM
For compound 3 the middle estimate is 1.2-fold (0.07 log units) above the measured one, and the stated range covers the measured number.
By their numbers in this assay, from the lowest: compounds 3, 2 and 1 (each within the scatter of the next).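

In this assay, 4-chlorophenyl in place of 3-methylphenyl on the saturated ring carbon gives a 1.1-fold lower number from compound 2 to compound 3 (0.04 log units; within the scatter), so exchanging one substituted pendant ring for another also leaves the compounds inseparable. A chlorine added to the pendant ring gives a 1.6-fold lower number from compound 1 to compound 3 (0.20 log units; within the scatter), which shows that a halogen on this ring, like the methyl of compound 2, cannot be set apart from the unsubstituted phenyl of compound 1. No measurement at hand offers an explanation for these numbers.

As far as these compounds go, whether an amine or a carboxylic acid on the pendant ring, or a longer chain at the same saturated ring carbon, would stay within the scatter remains open. From the compounds shown here alone, all three compounds also carry the 3,4-dichlorophenyl group unchanged, so the effect of replacing it is open too.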